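The compounds below may be only part of what the source reports. "The series", "measured", "known", "first", "only" and "open" are said of these compounds alone.

Inhibition in a functional assay on NCI-H460 cells (Homo sapiens) for inhibition, read by sulforhodamine B assay, with a stated time of 72 h; on this read-out lower numbers stand for stronger inhibition and higher numbers for weaker inhibition:
- compound 1 `CCOC(=O)c1noc2c1CN(C(=O)c1ccc(O)cc1O)CC2`: > 20000 nM (a limit of the assay, not a number)
- compound 2 `CCNC(=O)c1noc2c1CN(C(=O)c1cc(Cl)c(O)cc1O)CC2`: 9700 nM

Within the data shown here, compound 2 holds the only actual number so far in this assay, so its standing can be read only against one limit, (the limit of > 20000 nM in this assay, at which 1 of the 2 values shown sits).

Compound 3 `CCNC(=O)c1noc2c1CN(C(=O)c1ccc(O)cc1O)CC2` is compound 2 with a single change: hydrogen in place of chloro on an aromatic carbon, ortho to a hydroxy group and para to a hydroxy group. Among the measured compounds shown here, no measured pair isolates this change. Compound 1 also has hydrogen on that carbon, though it differs elsewhere too, and it reads > 20000 nM, which is a limit.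

A modest step toward weaker inhibition, meaning a higher number, is expected, possibly not beyond the scatter. The expected size is a 1.9-fold higher number from compound 2 to compound 3 (0.27 log units; within the scatter). For compound 3 the estimate is 18000 nM, with an expected range of 8000 nM to 40000 nM.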

Compound 3, half-maximal inhibitory concentration: > 20000 nM
Compound 3: only a limit was reported (the forecaster's own chance of this, stated with the estimate: 45%); middle value at least 1.1-fold (0.04 log units) from the limit.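

In this assay, hydrogen in place of chloro on the aromatic carbon ortho to a hydroxy group and para to a hydroxy group gives an at least 2.0-fold higher number from compound 2 to compound 3 (0.31 log units; beyond the scatter). Among these compounds, this is the first pair that isolates this position: with the ethylamino carbonyl held constant, the chloro alone separates a measured number from a limit. As far as these compounds go, the step has a lower bound only, and its full size stays unknown, as compound 3 reports a limit and not a number: the limit of > 20000 nM in this assay, at which 2 of the 3 values shown sit.

The step from compound 1 to compound 3 cannot be read, as both compounds report limits, so ethoxy against ethylamino on the carbonyl carbon remains unresolved here. Also open, from the compounds shown here alone, is whether the gain is specific to chloro or extends to bromo, methyl or a nitrile on the same aromatic carbon.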